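A few compounds are considered here, and "the series" means these few. Any claim that something is new, unique, unknown or untested is made for them only; others in the source may bear on it.

In an ADME assay on L6 cells (Rattus norvegicus) for cytotoxicity, read by resazurin assay, with a stated time of 70 h (a higher number here means a weaker inhibitor, a lower number a stronger inhibitor), compound 1 `COc1cc(NC(C)CCCNC(=O)/C=C/c2ccccc2)c2ncccc2c1` gives 18500 nM. Compound 2 `COc1ccc(/C=C/C(=O)NCCCC(C)Nc2cc(OC)cc3cccnc23)cc1` reaches only a limit of this assay, > 240000 nM. For the measured compounds named here, the single measured change, an at least 12-fold higher number from compound 1 to compound 2 (1.11 log units; beyond the scatter), is bounded in size by the limit of > 240000 nM in this assay, at which 1 of the 3 values shown sits. Compound 3 `COc1cc(NC(C)CCCNC(=O)NCc2ccncc2)c2ncccc2c1` has no result in this assay, "not determined" (no result reported), so it stands nowhere among these numbers. Compound 4 `COc1cc(NC(C)CCCNC(=O)NNC(=O)Nc2cccc(Cl)c2)c2ncccc2c1` differs from it in one place: ((3-chlorophenyl)carbamoyl)amino in place of (pyridin-4-yl)methyl on an amide-type nitrogen. Going by the values given here, the one measured step concerns a methoxy on an aromatic carbon, far from the amide-type nitrogen that is changed here, so it does not bear on this change; no step speaks to its direction, and no movement beyond the scatter can be predicted. Compound 4 is therefore expected near 30000 nM, in a range from 8000 nM to 200000 nM.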

Compound 4, half-maximal inhibitory concentration: 58600 nM
Compound 4: the middle estimate sits 2.0-fold (0.29 log units) below what was measured; the measured number falls inside the stated range.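

Compound 3 has no number to set against compound 4, so no new step can be read from this pair. The compounds shown leave open how ((3-chlorophenyl)carbamoyl)amino in place of (pyridin-4-yl)methyl moves the number in this assay, and nothing shown bears on this result.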